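Sulfonate aryl variations in the series

The source may hold more compounds than are shown below. What is called first, only, known or untested is meant among the compounds shown, and "the series" means these compounds.

Measured so far:
compound 1 `CNC(=O)/C=C1/COc2cc(OS(=O)(=O)c3ccccc3)ccc21`: 34 nM
compound 2 `CNC(=O)/C=C1/COc2cc(OS(=O)(=O)c3cccc(C#N)c3)ccc21`: 19 nM
compound 3 `CNC(=O)/C=C1/COc2cc(OS(=O)(=O)c3ccc(C(C)=O)cc3)ccc21`: 29 nM

All three numbers come from an assay (strain Sprague-Dawley) for inhibition of Amine oxidase [flavin-containing] A (Rattus norvegicus), read by spectrophotometry, with a stated time of 5 min; a higher number here means a weaker inhibitor, a lower number a stronger inhibitor. Compound 2 stands at the low end of the three, but its separation from compound 3 (a 1.5-fold higher number from compound 2 to compound 3 (0.18 log units; within the scatter)) and from compound 1 (a 1.8-fold lower number from compound 1 to compound 2 (0.25 log units; within the scatter)) is within the scatter, so no ranking among them holds.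

Compound 4 `CNC(=O)/C=C1/COc2cc(OS(=O)(=O)c3ccc(OC)cc3)ccc21` differs from compound 2 in one place: 4-methoxyphenyl in place of 3-cyanophenyl on a sulfonyl sulfur. The step that bears most on it is the other swap on the sulfonyl sulfur, a 1.5-fold higher number from compound 2 to compound 3 (0.18 log units; within the scatter), within the scatter; the ring-substituent steps a 1.8-fold lower number from compound 1 to compound 2 (0.25 log units; within the scatter) and a 1.2-fold lower number from compound 1 to compound 3 (0.07 log units; within the scatter) are likewise within scatter. Nothing measured moves this assay beyond its noise, so no step beyond the scatter is expected. Compound 4 is therefore estimated at 28 nM (range 12 nM to 65 nM). This estimate amounts to an expected step of a 1.5-fold higher number from compound 2 to compound 4 (0.17 log units; within the scatter).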

Compound 4, half-maximal inhibitory concentration: 11 nM
Beside the measured number, compound 4's estimate is 2.5-fold (0.41 log units) above it; the whole stated range lies above it.
By their numbers in this assay, from the lowest: compounds 4, 2, 3 and 1 (each within the scatter of the next, the first and the last beyond it).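

In this assay, this aromatic ring on the sulfonyl sulfur now gives steps beyond the scatter: methoxy in place of hydrogen (a 3.1-fold lower number from compound 1 to compound 4 (0.49 log units; beyond the scatter)) and methoxy in place of acetyl (a 2.6-fold lower number from compound 3 to compound 4 (0.42 log units; beyond the scatter)), whereas the earlier cyano and acetyl steps stayed within it. The swap of 3-cyanophenyl for 4-methoxyphenyl remains within the scatter (a 1.7-fold lower number from compound 2 to compound 4 (0.24 log units; within the scatter)), so these two groups are not ranked. No measurement on hand accounts for these steps.

Open, as far as these compounds go, is whether ethoxy, a longer chain, keeps the number of the methoxy compound. From the compounds shown here alone, an amine or a carboxylic acid on the same aromatic carbon also remains untested in these compounds.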